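This account rests on a few compounds, and the source may have more. Where it says the series, first, only, none or still open, it means among the compounds named here.

In a functional assay on KB cells (nasopharynx, Homo sapiens) for antiproliferative activity (on this read-out higher numbers stand for weaker inhibition and lower numbers for stronger inhibition), compound 1 `COc1ccc(S(=O)(=O)Nc2cccc3cc[nH]c23)cc1` gives 0.67 ug/mL, compound 2 `COc1ccc(S(=O)(=O)Nc2cccc3c(C#N)c[nH]c23)cc1` gives 1.4 ug/mL, and compound 3 `N#Cc1cccc(S(=O)(=O)Nc2cccc3c(C#N)c[nH]c23)c1` gives 8.2 ug/mL. Compound 2 therefore has the second highest of the three numbers, closer to compound 1 than to compound 3. Compound 4 `N#Cc1c[nH]c2c(NS(=O)(=O)c3ccc(C(=O)O)cc3)cccc12` is still unmeasured and departs from compound 2 in one place: carboxy in place of methoxy on an aromatic carbon. This puts carboxy in place of methoxy on an aromatic carbon, para to a large group.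

Going by the values given here, only one measured step links two compounds that differ in one place: a 2.1-fold higher number from compound 1 to compound 2 (0.32 log units; beyond the scatter). It is a modest step, with cyano in place of hydrogen on an aromatic carbon, and it does not involve the methoxy group, so it bears on the new change only indirectly. Among the compounds with values here, no measured compound carries a carboxy group. The closest guide is compound 3, which also has no methoxy group and gives 8.2 ug/mL, a higher number than that of compound 2. On that limited evidence, the expected change is an 8.6-fold higher number from compound 2 to compound 4 (0.93 log units; beyond the scatter), towards weaker inhibition in this assay, and it remains quite uncertain. Compound 4 is expected to give about 12 ug/mL, with an estimated range from 3 ug/mL to 50 ug/mL.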

Compound 4, half-maximal inhibitory concentration: > 100 ug/mL
Compound 4 was reported as a limit (the forecaster's own chance of this, stated with the estimate: 25%); middle value at least 8.3-fold (0.92 log units) from the limit.
By their numbers in this assay, from the lowest: compound 1; then compound 2; then compound 3. At a limit, above all of these: compound 4.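

In this assay compound 4 stands as a limit and not as a number: the limit of > 100 ug/mL in this assay, at which 1 of the 4 values shown sits.

Carboxy in place of methoxy on an aromatic carbon, para to a large group, gives an at least 71-fold higher number from compound 2 to compound 4 (1.85 log units; beyond the scatter), a large step towards weaker inhibition, while the only earlier step, a 2.1-fold higher number from compound 1 to compound 2 (0.32 log units; beyond the scatter), is modest and lies elsewhere in the structure. This is the first step shown that changes the group at this position, and it shows that the read-out depends strongly on what sits there, with the rest of compound 2 left unchanged.

The compounds shown leave open whether this shift belongs to the entering carboxy or to the departure of methoxy, since this single replacement cannot separate the two. A methyl ester, a primary amide or an amine at the same position would help to tell these apart, and carboxy on the core of compound 1, without the cyano group, would show whether the step depends on that group.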